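Benzyloxy substitution on the thiadiazole analogue of compound 3

The compounds below may be only part of what the source reports. "The series", "measured", "known", "first", "only" and "open" are said of these compounds alone.

Measured so far, all in a functional assay on the whole organism (stomach) with Rattus norvegicus as the target; a lower number here means that less compound is needed, a higher number that more compound is needed for the effect:
- compound 1 `Cc1nc2ccccn2c1C(C)SCCNc1n[s+]([O-])nc1N`: >> 25 mg/kg, a limit of the assay
- compound 2 `Cc1nc2c(OCc3ccccc3)cccn2c1C(C)SCCNc1n[s+]([O-])nc1N`: >> 25 mg/kg, a limit of the assay
- compound 3 `Cc1nc2ccccn2c1C(C)SCCNc1nsnc1N`: >> 25 mg/kg, a limit of the assay

Compound 3 stands where every value of the series stands: at a limit, not a number. The same holds for compound 1 and for compound 2, so that the limit of >> 25 mg/kg in this assay, at which 3 of the 3 values shown sit, summarises the whole picture in this assay.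

The next compound is compound 4 `Cc1nc2c(OCc3ccccc3)cccn2c1C(C)SCCNc1nsnc1N`. It differs from compound 3 by benzyloxy in place of hydrogen on an aromatic carbon.

Within the data shown here, two measured steps bear on it. The step from compound 1 to compound 2 is the same exchange on the same position of the core, and it reads a step that the two limits leave unreadable from compound 1 to compound 2. The step from compound 1 to compound 3 is a step that the two limits leave unreadable from compound 1 to compound 3. Neither gives a size, since both ends of each step are limits.

With no readable step in hand, the expectation for compound 4 is that it stays where compound 3 stands, and the estimated step that the limit leaves unreadable from compound 3 to compound 4 is therefore small. Compound 4 is expected to give about 50 mg/kg in this assay, with a range from 20 mg/kg to 250 mg/kg, most likely reported again as a limit.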

Compound 4, dose for half-maximal effect: >> 25 mg/kg
Compound 4: no number, only a limit; the forecaster's own chance of this, stated with the estimate: 80%; the middle value lies beyond the limit too.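

Compound 4 gives >> 25 mg/kg, a limit of the assay and not a number, so its steps from compound 3 and compound 2 cannot be read. The series sits at one limit: the limit of >> 25 mg/kg in this assay, at which 4 of the 4 values shown sit. The compounds shown leave open whether benzyloxy or the exchange of the group on the amine nitrogen alters the dose needed in this assay at all.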